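This account rests on a few compounds, and the source may have more. Where it says the series, first, only, none or still open, it means among the compounds named here.

Measured compounds in an ADME assay on MT4 cells (Homo sapiens) for cytotoxicity, read by MTT assay, with a stated time of 4 days; a higher number here means that more compound is tolerated, a lower number that less compound is tolerated:

compound 1 `Cc1cccc(-c2cc(C)c(Nc3ccnc(Nc4ccc(C#N)cc4)n3)c(C)c2)c1` gives 3670 nM
compound 2 `Cc1cc(-c2ccccc2F)cc(C)c1Nc1ccnc(Nc2ccc(C#N)cc2)n1` gives 2120 nM
compound 3 `Cc1cc(-c2ccc(C(F)(F)F)cc2)cc(C)c1Nc1ccnc(Nc2ccc(C#N)cc2)n1` gives 4160 nM

Compound 2 has the lowest of the three numbers, but all three sit close together: a 1.7-fold lower number from compound 1 to compound 2 (0.24 log units; within the scatter) and a 2.0-fold higher number from compound 2 to compound 3 (0.29 log units; within the scatter) are both within the scatter, as is a 1.1-fold higher number from compound 1 to compound 3 (0.05 log units; within the scatter). On this assay the three measured compounds are therefore indistinguishable.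

Compound 4 `Cc1cc(-c2cccc(Cl)c2)cc(C)c1Nc1ccnc(Nc2ccc(C#N)cc2)n1` is not yet measured. Its change from compound 2 is 3-chlorophenyl in place of 2-fluorophenyl on an aromatic carbon. Within the data shown here, the steps that bear on it are those exchanging the same aryl group on the same aromatic carbon, namely a 1.7-fold lower number from compound 1 to compound 2 (0.24 log units; within the scatter), a 1.1-fold higher number from compound 1 to compound 3 (0.05 log units; within the scatter) and a 2.0-fold higher number from compound 2 to compound 3 (0.29 log units; within the scatter); none of them left the scatter, whether the substituent on that ring was a methyl, a fluorine or a trifluoromethyl at various positions. No step beyond the scatter is therefore expected in this assay for compound 4 either.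

Compound 4 is estimated at 3000 nM, with a range of 1500 nM to 6000 nM. This corresponds to an expected step of a 1.4-fold higher number from compound 2 to compound 4 (0.15 log units; within the scatter), which would leave compound 4 within the band the other three occupy.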

Compound 4, half-maximal cytotoxic concentration: 2160 nM
Compound 4: the middle estimate sits 1.4-fold (0.14 log units) above what was measured; the measured number falls inside the stated range.
By their numbers in this assay, from the lowest: compounds 2, 4, 1 and 3 (each within the scatter of the next).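

In this assay, 3-chlorophenyl joins the aryl groups that show no separation at this aromatic carbon: the exchange from 2-fluorophenyl (a 1.0-fold higher number from compound 2 to compound 4 (0.01 log units; within the scatter)) and the exchange from 4-(trifluoromethyl)phenyl (a 1.9-fold lower number from compound 3 to compound 4 (0.28 log units; within the scatter)) both stay within the scatter. Among these compounds, the first direct exchange of one substituent at a single ring position, chloro for methyl between 3-methylphenyl and 3-chlorophenyl (a 1.7-fold lower number from compound 1 to compound 4 (0.23 log units; within the scatter)), is also within the scatter, so all four compounds remain indistinguishable here. No measurement on hand offers an explanation for these numbers.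

All four compounds carry a phenyl ring with a methyl, halogen or trifluoromethyl substituent at this carbon, so the compounds shown leave open whether an amine or a carboxylic acid on that ring would stay within the same band. The same question stands for a morpholine or a longer alkyl chain in place of the aryl group.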